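Replacing fluoro with 3,5-dimethoxyphenyl on the benzylamide ring

The source may report more compounds than this note shows. Statements on the series, on what has been measured and on what is new or still open speak of the compounds shown alone.

Measured compounds:
compound 1 `CC(C(=O)NCc1ccc(C(F)(F)F)cc1N1CCCC1)c1ccc(NS(C)(=O)=O)c(F)c1` gives 2.3 nM
compound 2 `CC(C(=O)NCc1ccc(C(F)(F)F)cc1OC1CCCCC1)c1ccc(NS(C)(=O)=O)c(F)c1` gives 0.7 nM
compound 3 `CC(C(=O)NCc1ccc(C(F)(F)F)cc1F)c1ccc(NS(C)(=O)=O)c(F)c1` gives 68.7 nM

All three were run in an assay on CHO cells for antagonist activity at transient receptor potential cation channel subfamily V member 1 (Homo sapiens), read by FLIPR; a lower number here means a stronger inhibitor, a higher number a weaker inhibitor. Compound 3 stands at the highest number of the three, well apart from the others: a 30-fold higher number from compound 1 to compound 3 (1.48 log units; beyond the scatter), and a 98-fold higher number from compound 2 to compound 3 (1.99 log units; beyond the scatter), both beyond the scatter. The two non-fluoro substituents at that carbon sit close together, with only a modest gap: a 3.3-fold lower number from compound 1 to compound 2 (0.52 log units; beyond the scatter).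

Compound 4 `COc1cc(OC)cc(-c2cc(C(F)(F)F)ccc2CNC(=O)C(C)c2ccc(NS(C)(=O)=O)c(F)c2)c1` has not yet been measured. It differs from compound 3 by 3,5-dimethoxyphenyl in place of fluoro on an aromatic carbon. Both measured steps into compound 3 replaced a larger group at this carbon with fluoro and cost a large amount of potency; the step to compound 4 runs the other way, putting a larger group back in place of fluoro. A large drop in the number in this assay is therefore expected, a 23-fold lower number from compound 3 to compound 4 (1.36 log units; beyond the scatter), landing compound 4 in the region occupied by compound 1 and compound 2. The estimate for compound 4 in this assay is 3 nM, with a range from 0.7 nM to 15 nM.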

Compound 4, inhibition constant: 5.8 nM
Estimate against measurement, compound 4: 1.9-fold (0.29 log units) below, within the range that was stated.
By their numbers in this assay, from the lowest: compound 2; then compound 1; then compound 4; then compound 3.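

In this assay, a carbon-linked aromatic ring is accepted at this carbon, with a 12-fold lower number from compound 3 to compound 4 (1.07 log units; beyond the scatter) as the replacement of fluoro by 3,5-dimethoxyphenyl recovers much of the potency, so the gain over fluoro is not confined to the pyrrolidin-1-yl and cyclohexyloxy groups. The three larger groups are nevertheless not interchangeable: the aryl group falls short of both, with a 2.5-fold higher number from compound 1 to compound 4 (0.40 log units; beyond the scatter) against pyrrolidin-1-yl and an 8.3-fold higher number from compound 2 to compound 4 (0.92 log units; beyond the scatter) against cyclohexyloxy, both modest steps. Nothing available explains these differences.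

An unsubstituted phenyl ring or a pyridine ring at this carbon would separate the contribution of the aromatic ring from that of the two methoxy groups. A methyl group or a primary amine would show whether fluoro's position at the weak end of the series extends to other small groups.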